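Sulfonyl Aryl Swap Around Compound 2

The compounds below may be only part of what the source reports. "The series", "measured", "known", "first", "only" and "open" are said of these compounds alone.

Three analogues sharing one core were measured in an assay on isolated protein for binding affinity to 5-hydroxytryptamine receptor 6 (Homo sapiens), tested at 10 uM; a lower number here means less inhibition, a higher number more inhibition at the concentration tested (going by the name of the read-out): compound 1 `CC(C)Cc1cc(CNS(=O)(=O)c2cccc(Cl)c2)nn1-c1ccccc1` gives 40.8%, compound 2 `CC(C)Cc1cc(CNS(=O)(=O)c2ccc(C(C)(C)C)cc2)nn1-c1ccccc1` gives 51.1%, and compound 3 `CC(C)Cc1cc(CNS(=O)(=O)Cc2cccc3ccccc23)nn1-c1ccccc1` gives 28.7%. Compound 2 stands highest of the three, beyond the scatter from both others. Within the data shown here, the only measured comparison bearing on the next change is a number 10.3 percentage points higher from compound 1 to compound 2 (beyond the scatter). Compound 4 `Cc1c(Cl)cccc1S(=O)(=O)NCc1cc(CC(C)C)n(-c2ccccc2)n1` differs from compound 2 in one place: 3-chloro-2-methylphenyl in place of 4-(tert-butyl)phenyl on a sulfonyl sulfur. Among the measured compounds shown here, a chlorine-bearing phenyl returns in place of the 4-(tert-butyl)phenyl, which roughly reverses that earlier step, while the methyl in the entering group has no measured precedent. A modest drop in this assay is therefore expected, about a number 18.1 percentage points lower from compound 2 to compound 4 (beyond the scatter). Compound 4 is estimated at 33%, within 20% to 48%.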

Compound 4, a percentage reported as inhibition, at one concentration (the size of the read-out at that concentration, not a potency): 72.3%
Compound 4: middle estimate off by 39.3 percentage points, on the low side; the whole stated range lies below it.
By their numbers in this assay, from the lowest: compound 3; then compound 1; then compound 2; then compound 4.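

In this assay the change at the sulfonyl sulfur gives a number 21.2 percentage points higher from compound 2 to compound 4 (beyond the scatter), so a chlorine-bearing phenyl can outdo the 4-(tert-butyl)phenyl, which the earlier pair did not show. Methyl in place of hydrogen on an aromatic carbon of the 3-chlorophenyl gives a number 31.5 percentage points higher from compound 1 to compound 4 (beyond the scatter), the largest step among these compounds. Nothing available explains why this methyl has so large an effect. From the compounds shown here alone, it remains open whether a 2-methylphenyl without the chlorine would keep the gain, and whether a methoxy group or an amine in place of that methyl would.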